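The source may report more compounds than this note shows. Statements on the series, on what has been measured and on what is new or still open speak of the compounds shown alone.

In an ADME assay on L02 cells (Homo sapiens) for inhibition, read by CCK-8 assay, with a stated time of 48 h (on this read-out lower numbers stand for stronger inhibition of growth and higher numbers for weaker inhibition of growth), three compounds built on a shared core have been measured, and a fourth still awaits its number. Compound 1 `Cc1ccccc1Nc1nc(NCc2ccco2)ncc1Cl` gives only a limit of > 100000 nM, so the assay reports no number for it. That limit is the one described as the limit of > 100000 nM in this assay, at which 1 of the 3 values shown sits. Compound 2 `CCN1CCN(c2ccc(Nc3ncc(Cl)c(Nc4ccccc4C)n3)cc2)CC1` gives 970 nM. Compound 3 `COc1ccccc1CNc1nc(Nc2ccc(N3CCN(C)CC3)cn2)ncc1Cl` gives 25500 nM, the highest of the two numbers shown; the nearest is compound 2, whose number lies well below it, a gap beyond the usual scatter of repeated measurements.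

Compound 4 `COc1ccc(Nc2nc(Nc3ccc(N4CCN(C)CC4)cn3)ncc2Cl)cc1` differs from compound 3 in one place: 4-methoxyphenyl in place of 2-methoxybenzyl on a nitrogen on an aromatic ring. Read one bond further out, the change takes (2-methoxybenzyl)amino to (4-methoxyphenyl)amino. Among the compounds with values here, no step between two measured compounds differing in a single place is available, so the size of the expected step must be judged from the whole set. Like compound 4, compound 2 bears an aromatic ring on the amino nitrogen with no 2-methoxybenzyl in between, and compound 2 gives 970 nM, while compound 3 gives 25500 nM. Compound 4 is therefore expected to sit lower, by a step of a 6.4-fold lower number from compound 3 to compound 4 (0.80 log units; beyond the scatter), which should exceed the scatter. The estimate for compound 4 is 4000 nM, with a range from 1000 nM to 20000 nM.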

Compound 4, concentration for 50% growth inhibition: 3150 nM
Estimate against measurement, compound 4: 1.3-fold (0.10 log units) above, and the stated range covers the measured number.
By their numbers in this assay, from the lowest: compound 2; then compound 4; then compound 3. At a limit, above all of these: compound 1.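

In this assay, within the data shown here, putting 4-methoxyphenyl in place of 2-methoxybenzyl on this nitrogen gives an 8.1-fold lower number from compound 3 to compound 4 (0.91 log units; beyond the scatter) and so stronger inhibition of growth, the first measured change at a single place in this set, and one that lies beyond the scatter. The counted features of the two groups barely differ: each has one six-membered aromatic ring of carbon only, one hydrogen-bond acceptor and no donor, and the entering group has 8 heavy atoms against 9, yet this small swap still moves the number clearly, although it alters two things at once, the carbon link to the ring and the place of the methoxy group named in each group. Nothing measured here explains the direction or size of this step.

The compounds shown leave open which of those two alterations carries the step, a question that 2-methoxyphenyl or 4-methoxybenzyl on the same nitrogen would help to separate. Also open, on these data alone, is how this position responds to a plain phenyl without methoxy, or to a ring bearing an amine or a carboxylic acid instead.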